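Chloro into the carboxyphenyl end: outlook for compound 4

This account rests on a few compounds, and the source may have more. Where it says the series, first, only, none or still open, it means among the compounds named here.

Measured in an assay on HEK293 cells for positive allosteric modulation of metabotropic glutamate receptor 2 (Rattus norvegicus), read by thallium flux, with a stated time of 2.5 min; on this read-out higher numbers stand for larger maximal responses and lower numbers for smaller maximal responses:
compound 1 `Cc1c(OCCCCOc2ccc(C(=O)O)cc2)ccc(C(=O)CC2CCCC2)c1O`: 82.6%
compound 2 `CCCC(=O)c1ccc(OCCCCOc2cc(C(=O)O)ccc2OC)c(C)c1O`: 82.8%
compound 3 `Cc1c(OCCCCOc2ccc(C(=O)O)cc2)ccc(C(=O)CC(C)C)c1O`: 88%

Compound 3 shows the highest of the three numbers, yet its distance to compound 2 and its distance to compound 1 both lie within the scatter, so the three compounds stand level on this read-out. For the measured compounds named here, the only step between two compounds that differ in one place is a number 5.4 percentage points higher from compound 1 to compound 3 (within the scatter); it concerns the saturated chain carbon bound to the carbonyl carbon and is within the scatter. Going by the values given here, compound 2 differs from the other two in more than one place, so no single step is defined for it; its value simply sits with the others.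

Compound 4 `Cc1c(OCCCCOc2ccc(C(=O)O)c(Cl)c2)ccc(C(=O)CC(C)C)c1O` differs from compound 3 by chloro in place of hydrogen on an aromatic carbon. Among the compounds with values here, no measured step touches the 4-carboxyphenyl end of the chain, so this change has no direct precedent. What the data do show is a flat maximal response across three compounds varied elsewhere. On that basis no step beyond the scatter is expected in this assay; the expected step is a number 3 percentage points lower from compound 3 to compound 4 (within the scatter). Compound 4 is estimated at 85%, with a range from 70% to 98%.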

Compound 4, largest response reached (reported as percent of maximum), in percent of the reference or control that the assay uses: 80.5%
Compound 4: middle estimate off by 4.5 percentage points, on the high side; low and high end bracket the measured number.
By their numbers in this assay, from the lowest: compounds 4, 1, 2 and 3 (each within the scatter of the next).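

At the 4-carboxyphenyl end, the change to 4-carboxy-3-chlorophenyl places chloro on an aromatic carbon, ortho to a carboxy group, and gives in this assay a number 7.5 percentage points lower from compound 3 to compound 4 (within the scatter). For the compounds shown here, this is the only one-place step at this end of the chain, and it shows that compound 3 and compound 4 stand level on maximal response, so a single chlorine at this position, with the carboxy group kept, does not separate the pair on this read-out. No measurement at hand bears on what lies behind this step.

With only one substituent and one position covered at this end, the compounds shown leave open whether fluoro or bromo on the same aromatic carbon would also stay level with compound 3, and whether chloro elsewhere on that ring would do the same. They also leave open whether the chloro step would read the same on the cyclopentyl ketone of compound 1, and whether it would stay level on any read-out other than maximal response.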